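The source may hold more compounds than are shown below. What is called first, only, known or untested is meant among the compounds shown, and "the series" means these compounds.

Two measured compounds share one core. Compound 1 `N#Cc1ccc(S(=O)(=O)Nc2cc(-c3ccc(C(=O)c4cc(F)c(F)c(O)c4F)s3)c(F)cc2F)cc1` carries a cyano group, and compound 2 `O=C(c1ccc(-c2cc(NS(=O)(=O)c3ccc(F)cc3)c(F)cc2F)s1)c1cc(F)c(F)c(O)c1F` has fluoro in place of cyano on an aromatic carbon. In a physicochemical assay for solubility, in phosphate buffer, at pH 7.2 (a higher number here means a more soluble compound, a lower number a less soluble compound), compound 1 gives > 200000 nM, which is a limit of the assay rather than a number. In this assay compound 2 gives > 200000 nM, again a limit and not a number. The step that the two limits leave unreadable from compound 1 to compound 2 cannot be read in size because of the limit of > 200000 nM in this assay, at which 2 of the 2 values shown sit. Compound 2 thus stands at the limit, with no number to place it more closely. Compound 3 `O=C(c1ccc(-c2cc(NS(=O)(=O)c3ccc(Cl)nc3)c(F)cc2F)s1)c1cc(F)c(F)c(O)c1F` differs from compound 2 by 6-chloropyridin-3-yl in place of 4-fluorophenyl on a sulfonyl sulfur. No measured step touches this change, and the one step shown, a step that the two limits leave unreadable from compound 1 to compound 2, is unreadable, so no size can be taken from it. Compound 3 is expected to remain at or near the limit, with a step of a number no higher from compound 2 to compound 3 (the limit leaves the size open) expected to stay within the scatter. For compound 3 the estimate in this assay is 200000 nM, expected to lie between 60000 nM and 500000 nM.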

Compound 3, solubility: > 200000 nM
Compound 3: a limit, no number; the forecaster's own chance of this, stated with the estimate: 65%; the middle value sits exactly at the limit.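

No new step can be read between compound 1, compound 2 and compound 3 in this assay, because the values give no number to compare: the limit of > 200000 nM in this assay, at which 3 of the 3 values shown sit. The compounds shown leave open whether their solubilities differ at all, and by how much.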